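Methoxy in Place of Chloro on an Allenyl Amine

The source may hold more compounds than are shown below. What is called first, only, known or untested is meant among the compounds shown, and "the series" means these compounds.

Compound 1, `C=C=CCN(C)Cc1ccccc1`: in an assay on forebrain for inhibition of Monoamine oxidase (Mus musculus) (on this read-out lower numbers stand for an effect already at smaller amounts and higher numbers for an effect only at larger amounts of compound), compound 1 gives > 48 umol/kg.
Compound 2, `C=C=C(CN)Cc1ccc(Cl)cc1`: in this assay compound 2 gives 18 umol/kg.

The result for compound 1 is a limit of the assay, not a number. Compound 2 therefore stands alone with the only real figure, and the other entry is the limit described by the limit of > 48 umol/kg in this assay, at which 1 of the 2 values shown sits. Among the compounds with values here, no pair of measured compounds differs in a single place, so no measured step is available.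

Compound 3, `C=C=C(CN)Cc1ccc(OC)cc1`, differs from compound 2 by methoxy in place of chloro on an aromatic carbon. Within the data shown here, with no comparable step among the measured compounds, a small shift toward higher doses in this assay is expected, possibly not beyond the scatter. The step from compound 2 to compound 3 is estimated at a 1.7-fold higher number from compound 2 to compound 3 (0.22 log units; within the scatter). Compound 3 is expected to reach 30 umol/kg, within 12 umol/kg to 80 umol/kg.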

Compound 3, dose for half-maximal effect: 39 umol/kg
For compound 3 the middle estimate is 1.3-fold (0.11 log units) below the measured one; the measured number falls inside the stated range.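

In this assay, within the data shown here, replacing chloro with methoxy on an aromatic carbon gives a 2.2-fold higher number from compound 2 to compound 3 (0.34 log units; beyond the scatter), the first measured step. It shows that the read-out responds to a change at this place, para to a group of 6 heavy atoms, although only modestly, with the higher number on the methoxy side. Compound 1 remains a limit of the assay and not a number, and it adds no step to this comparison: the limit of > 48 umol/kg in this assay, at which 1 of the 3 values shown sits.

Among these compounds, the single step cannot separate the loss of chloro from the arrival of methoxy, with its added hydrogen-bond acceptor, and it gives no cause for the shift. The compounds shown also leave open how fluoro, methyl or an amine at this same place would read in this assay.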